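A methoxy added to the most potent quinazolinone hydrazide

The compounds below may be only part of what the source reports. "The series", "measured", "known", "first", "only" and "open" are said of these compounds alone.

Compound 1, `CCOC(=O)CNn1c(C)nc2ccccc2c1=O`, gives 26800 nM in a functional assay on SF-268 cells (Homo sapiens) for inhibition, read by sulforhodamine B assay, with a stated time of 48 h; on this read-out higher numbers stand for weaker inhibition of growth and lower numbers for stronger inhibition of growth.
Compound 2, `Cc1nc2ccccc2c(=O)n1NC(=O)c1cc2ccccc2o1`, gives 22300 nM in this assay.
Compound 3, `Cc1nc2ccccc2c(=O)n1NC(=O)/C(Cl)=C/c1ccccc1`, gives 50 nM in this assay.

Compound 3 has the lowest number of the three in this assay; its nearest neighbour is compound 2, and the gap between them is well beyond the scatter, as is the still larger gap to compound 1. Compound 4, `COc1ccc(/C=C(\Cl)C(=O)Nn2c(C)nc3ccccc3c2=O)cc1`, differs from compound 3 in one place: methoxy in place of hydrogen on an aromatic carbon. Among the compounds with values here, no pair of measured compounds shows what this change does, so the expectation rests on the single number for compound 3 alone. The step from compound 3 to compound 4 in this assay is expected to be small, a 1.2-fold higher number from compound 3 to compound 4 (0.08 log units; within the scatter), in no clear direction and probably not beyond the scatter. Compound 4 is therefore expected to give about 60 nM in this assay, within a range from 15 nM to 250 nM.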

Compound 4, concentration for 50% growth inhibition: 800 nM
Estimate against measurement, compound 4: 13-fold (1.12 log units) below, and the stated range ends below it.
By their numbers in this assay, from the lowest: compound 3; then compound 4; then compounds 2 and 1 (each within the scatter of the next).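

The change from phenyl to 4-methoxyphenyl is the only one-place change among the compounds shown, and it gives a 16-fold higher number from compound 3 to compound 4 (1.20 log units; beyond the scatter) in this assay as the first direct reading of any substitution in this series. Within the data shown here, it shows that the aromatic carbon para to a large group is not a place where a substituent passes unnoticed: adding a methoxy there weakens growth inhibition by a step well beyond the scatter, although only this one group has been read at this position. Nothing measured here accounts for that loss.

Going by these compounds, whether a fluorine, a methyl or an amine on the same carbon would weaken growth inhibition to a similar degree remains open. So does whether a methoxy on another carbon of that ring, or a hydrogen in place of the chlorine, would shift the number at all.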